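Swapping the Bicyclic Ring on the Urea Nitrogen

The source may hold more compounds than are shown below. What is called first, only, known or untested is meant among the compounds shown, and "the series" means these compounds.

Two compounds share a core and differ only in the bicyclic aromatic group attached to the urea nitrogen. Compound 1 `CC1CCN(c2nc(C(F)(F)F)ccc2CNC(=O)Nc2cnc3ccccc3c2)CC1` carries a quinolin-3-yl group and gives 9.5 nM in an assay on isolated protein for antagonist activity at transient receptor potential cation channel subfamily V member 1 (Homo sapiens), read by FLIPR; on this read-out higher numbers stand for weaker inhibition and lower numbers for stronger inhibition. Going by the values given here, compound 2 `CC1CCN(c2nc(C(F)(F)F)ccc2CNC(=O)Nc2cccc3cnccc23)CC1` carries an isoquinolin-5-yl group and gives 0.2 nM in this assay, the lowest of the two numbers seen; the only step measured so far is a 48-fold lower number from compound 1 to compound 2 (1.68 log units; beyond the scatter), showing that the choice of bicyclic ring at this position strongly affects inhibition.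

Compound 3 `CC1CCN(c2nc(C(F)(F)F)ccc2CNC(=O)Nc2cccc3nccnc23)CC1` is not yet measured. The change is quinoxalin-5-yl in place of isoquinolin-5-yl on an amide-type nitrogen. The point of attachment of the ring stays the same, and only the second ring gains an additional nitrogen. Among the compounds with values here, no measured step covers this exact exchange, so the one large step from compound 1 to compound 2 offers only the general lesson that this position is sensitive, not its direction here. The expectation for compound 3 is therefore a modest shift, a 3.0-fold higher number from compound 2 to compound 3 (0.48 log units; beyond the scatter), with an estimated value of 0.6 nM and a likely range from 0.1 nM to 4 nM in this assay.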

Compound 3, inhibition constant: 48.1 nM
The estimate for compound 3 lay 80-fold (1.90 log units) below the measured number; the measured number lies above the stated range.
By their numbers in this assay, from the lowest: compound 2; then compound 1; then compound 3.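

The exchange of isoquinolin-5-yl for quinoxalin-5-yl keeps both rings at the same size and the group on the same urea nitrogen, yet it gives a 240-fold higher number from compound 2 to compound 3 (2.38 log units; beyond the scatter) in this assay, so this position responds strongly to the ring nitrogens of the bicyclic group and not only to its overall shape. The comparison with the quinolin-3-yl group gives a 5.1-fold higher number from compound 1 to compound 3 (0.70 log units; beyond the scatter), which places the quinoxalin-5-yl group last of the three and shows that a bicyclic aromatic group containing nitrogen does not by itself secure a low number here. Nothing available explains why the two groups differ so sharply.

With only these three groups, the effect of the number of ring nitrogens cannot be separated from the effect of where they sit. A quinolin-5-yl group, with a single ring nitrogen, and a naphthalen-1-yl group, with none, would help to separate the two, and would show whether the low number of compound 2 depends on a ring nitrogen at all.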